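This account rests on a few compounds, and the source may have more. Where it says the series, first, only, none or still open, it means among the compounds named here.

In a functional assay on U-937 cells (Homo sapiens) for antiproliferative activity, read by MTT assay, with a stated time of 24 h (on this read-out higher numbers stand for weaker inhibition and lower numbers for stronger inhibition), compound 1 (`CCCCc1oc2ccccc2c1C(=O)c1ccc(OCC(=O)N2CCCCC2)cc1`) gives 37100 nM, compound 2 (`CCCCc1oc2ccccc2c1C(=O)c1ccc(OCC(=O)N[C@@H](C)c2ccccc2)cc1`) gives 33800 nM and compound 3 (`CCCCNC(=O)CCCOc1ccc(C(=O)c2c(CCCC)oc3ccccc23)cc1`) gives 24600 nM. Compound 3 does not stand apart from the other two, as a 1.5-fold lower number from compound 1 to compound 3 (0.18 log units; within the scatter) and a 1.4-fold lower number from compound 2 to compound 3 (0.14 log units; within the scatter) show. The next compound, compound 4 (`CCCCc1oc2ccccc2c1C(=O)c1ccc(OCCCC(=O)N2CCOCC2)cc1`), keeps everything in compound 3 except the group on the carbonyl carbon: morpholin-4-yl in place of butylamino on a carbonyl carbon. Among the measured compounds shown here, no measured step makes this exact exchange. The closest evidence is a 1.1-fold lower number from compound 1 to compound 2 (0.04 log units; within the scatter), where (1-phenylethyl)amino takes the place of piperidin-1-yl on a carbonyl carbon, a similar exchange between a ring and an open amine, though in the opposite sense. The two steps to compound 3 also bear on it, since they change this same part of the molecule along with the chain. All three stay within the scatter, so no step beyond the scatter is expected here, and no direction can be firmly called. The estimated change is a 1.3-fold higher number from compound 3 to compound 4 (0.11 log units; within the scatter). For compound 4 the expected value is 32000 nM, with an estimated range from 16000 nM to 65000 nM.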

Compound 4, half-maximal inhibitory concentration: 21400 nM
Estimate against measurement, compound 4: 1.5-fold (0.17 log units) above, within the range that was stated.
By their numbers in this assay, from the lowest: compounds 4, 3, 2 and 1 (each within the scatter of the next).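

In this assay the exchange on a carbonyl carbon whose other neighbour is a saturated chain carbon now has a direct reading, a 1.1-fold lower number from compound 3 to compound 4 (0.06 log units; within the scatter) and so replacing butylamino, with its hydrogen-bond donor, by morpholin-4-yl, which has none, leaves the number within the scatter. The wider changes at this end of the molecule agree, with a 1.6-fold lower number from compound 2 to compound 4 (0.20 log units; within the scatter) and a 1.7-fold lower number from compound 1 to compound 4 (0.24 log units; within the scatter) so that none of the four compounds stands apart from the others. Nothing available explains why this exchange leaves the number within the scatter.

The compounds shown leave open how a piperazine or a free carboxylic acid would read in place of morpholin-4-yl on this carbonyl carbon. Among the compounds shown here, with no step here beyond the scatter, it also remains open whether a longer chain to the carbonyl, or a group other than butyl on the shared core, would shift the number at all.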